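A few compounds are considered here, and "the series" means these few. Any claim that something is new, unique, unknown or untested is made for them only; others in the source may bear on it.

Values in a functional assay for inhibition, with Rattus norvegicus as the target; a higher number here means that more compound is needed for the effect, a lower number that less compound is needed:
- Compound 1 `CC[C@H](CC1CCCCC1)NCc1ccc(C(=O)N[C@@H](CCSC)C(=O)O)c(-c2ccccc2C)c1`: > 1000 nM, a limit of the assay and not a number
- Compound 2 `CSCC[C@H](NC(=O)c1ccc(CN[C@H](CCCC(C)C)CC2CCCCC2)cc1-c1ccccc1C)C(=O)O`: 52 nM
- Compound 3 `CSCC[C@H](NC(=O)c1ccc(CN(CCC2CCCCC2)C(=O)OC(C)(C)C)cc1-c1ccccc1C)C(=O)O`: 160 nM

Of the two exact values, compound 2 has the lower at 52 nM, and compound 3 has the higher at 160 nM. Compound 4 `CSCC[C@H](NC(=O)c1ccc(CN(CCC2CCCCC2)C(=O)c2ccccc2)cc1-c1ccccc1C)C(=O)O` differs from compound 3 by phenyl in place of tert-butoxy on a carbonyl carbon, with phenyl in place of tert-butoxy on a carbonyl carbon.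

Among the compounds with values here, the only measured step, an at least 19-fold lower number from compound 1 to compound 2 (1.28 log units; beyond the scatter), is large, but it concerns a saturated chain carbon rather than this carbonyl. It therefore shows that this assay can respond strongly to a structural change, but it does not predict this one. Within the data shown here, with no direct precedent, only a small expected change without a firm direction is estimated: a 1.1-fold lower number from compound 3 to compound 4 (0.03 log units; within the scatter). Compound 4 is expected at about 150 nM, with an estimated range of 40 nM to 600 nM.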

Compound 4, half-maximal effective concentration: > 1000 nM
Compound 4: no number, only a limit (the forecaster's own chance of this, stated with the estimate: 10%); middle value at least 6.6-fold (0.82 log units) away from the limit.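

In this assay, this carbonyl carbon proves sensitive to what it carries: phenyl in place of tert-butoxy gives an at least 6.2-fold higher number from compound 3 to compound 4 (0.79 log units; beyond the scatter). A change here, and not only on the saturated chain, can therefore move the number beyond the scatter. The result for compound 4 is a limit of the assay and not a number, so the step has no upper size: the limit of > 1000 nM in this assay, at which 2 of the 4 values shown sit.

From the compounds shown here alone, whether the loss of the oxygen or the arrival of the aromatic ring matters more remains open. Phenoxy or cyclohexyl on the same carbonyl carbon would separate the two.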